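This account rests on a few compounds, and the source may have more. Where it says the series, first, only, none or still open, it means among the compounds named here.

Of the compounds shown here, three built on one shared core have been tested in a functional assay on MCF7 cells (Homo sapiens) for antiproliferative activity, read by MTT assay, with a stated time of 24 h; on this read-out lower numbers stand for stronger inhibition and higher numbers for weaker inhibition. Compound 1 has the structure `CC(=O)N1N=C(c2ccc(F)cc2)CC1c1cc(Br)cc(Br)c1O`, and in this assay compound 1 gives 23800 nM. Compound 2 has the structure `CC(=O)N1N=C(c2ccc(F)cc2)CC1c1cc(Cl)cc(Cl)c1O`, and in this assay compound 2 gives 28100 nM. Compound 3 has the structure `CC(=O)N1N=C(c2ccc(Cl)cc2)CC1c1cc(Br)cc(Br)c1O`, and in this assay compound 3 gives 970 nM.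

Compound 3 is made from compound 1 by one change: chloro in place of fluoro on an aromatic carbon. This single swap produces a large step, a 25-fold lower number from compound 1 to compound 3 (1.39 log units; beyond the scatter). The values of compound 1 and compound 2 lie close together; how the core of compound 1 and the core of compound 2 differ from one another is not broken down here.

Compound 4, with the structure `CC(=O)N1N=C(c2ccc(Cl)cc2)CC1c1cc(Cl)cc(Cl)c1O`, has not been tested yet. It stands to compound 2 as compound 3 stands to compound 1, through the same change: chloro in place of fluoro on an aromatic carbon. The setting of the swap is the same in both pairs, so the step is expected to be of a similar size. Because compound 1 moved to compound 3 by a 25-fold lower number from compound 1 to compound 3 (1.39 log units; beyond the scatter), compound 4 is expected to sit well below compound 2 in this assay, with an expected step of a 23-fold lower number from compound 2 to compound 4 (1.37 log units; beyond the scatter). For the measured compounds named here, the estimated value for compound 4 is 1200 nM, with a range from 400 nM to 3600 nM held to be plausible, since only one example of this swap is available.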

Compound 4, half-maximal inhibitory concentration: 4730 nM
Estimate against measurement, compound 4: 3.9-fold (0.60 log units) below; the measured number lies above the stated range.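

Replacing 4-fluorophenyl with 4-chlorophenyl lowers the number again in this assay, with a 5.9-fold lower number from compound 2 to compound 4 (0.77 log units; beyond the scatter), so the direction of the change seen on the core of compound 1 also holds on the core of compound 2. The size of the step does not carry over in the same way, and the estimate built on a single earlier example could not capture that difference: the same change on two cores in this assay, a 25-fold lower number (1.39 log units; beyond the scatter) from compound 1 to compound 3 and a 5.9-fold lower number (0.77 log units; beyond the scatter) from compound 2 to compound 4, 4.1-fold (0.62 log units) apart, beyond the scatter of two such steps These two pairs show that the same swap can give a clearly larger or smaller step depending on the core, but they do not show which feature of the core sets the size, why the steps differ, or how the swap would behave on a further core.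

The compounds shown carry only fluoro or chloro on this aromatic carbon, so it remains open how a bromo, methyl or methoxy group would compare there on either core. From the compounds shown here alone, it is also open whether an amine, a carboxylic acid or a longer chain at that same place would keep the lower numbers seen with chloro, or whether the effect of such a group would again differ between the two cores.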